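Chlorinated coumarins and monoamine oxidase B

The source may hold more compounds than are shown below. What is called first, only, known or untested is meant among the compounds shown, and "the series" means these compounds.

Measured compounds:
compound 1, `O=C(c1ccccc1)c1cc2cc(Cl)ccc2oc1=O`: "not active" (no number reported)
compound 2, `O=C(c1ccccc1)c1cc2cc(Cl)cc(Br)c2oc1=O`: 40%

Of the compounds shown here, two have been tested in an in vitro assay on BTI-TN-5B1-4 cells for inhibition of Amine oxidase [flavin-containing] B (Homo sapiens), read by fluorescence, with a stated time of 15 min, tested at 100 uM; a lower number here means less inhibition, a higher number more inhibition at the concentration tested (going by the name of the read-out). Compound 1, with a benzoyl group on the shared core and a chlorine substituent, is reported in this assay simply as "not active" (no number reported), without a number. Adding a bromine substituent to the core of compound 1 gives compound 2, which in this assay gives 40%; this is the only numerical value available, so compound 2 stands alone among the measured compounds, and nothing more can be read from the comparison with compound 1 than that compound 1 earned no number at all.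

Compound 3, `O=C(O)c1cc2cc(Cl)cc(Br)c2oc1=O`, has not yet been measured. It differs from compound 2 in one place: hydroxy in place of phenyl on a carbonyl carbon. The ketone linking the core to a phenyl ring becomes a carboxylic acid. Among the compounds with values here, no measured pair in this set shows such a change, so the expected size of the step rests only on the single value of compound 2 and the nature of the change. A sizeable drop in inhibition is expected, well beyond the scatter of repeated measurements, so that compound 3 is expected to give 10%, between 0% and 35%, and the expected step of a number 30 percentage points lower from compound 2 to compound 3 (beyond the scatter) points downward.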

Compound 3, a percentage reported as inhibition, at one concentration (the size of the read-out at that concentration, not a potency): "not active" (no number reported)
The entry for compound 3 holds no number; no gap can be computed for the estimate.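

In this assay, within the data shown here, compound 3 gives "not active" (no number reported) and compound 2 gives 40%, so no step between these two compounds can be read. No measured evidence bears on this result. The compounds shown leave open how much inhibition is lost when hydroxy takes the place of phenyl, since only compound 2 carries a number.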